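A few compounds are considered here, and "the series" means these few. Any claim that something is new, unique, unknown or untested is made for them only; others in the source may bear on it.

Compound 3 `COc1ccc(CNCCCNS(=O)(=O)c2cc(C(F)(F)F)cc(C(F)(F)F)c2)cc1OC` stands at the top of the numbers seen so far: in a functional assay on A-431 cells (Homo sapiens) for inhibition, read by MTT assay, with a stated time of 72 h (on this read-out higher numbers stand for weaker inhibition of growth and lower numbers for stronger inhibition of growth), compound 3 gives 7000 nM, the highest of the three. Compound 1 `CC(C)(C)c1ccc(CNCCCNS(=O)(=O)c2cc(C(F)(F)F)cc(C(F)(F)F)c2)cc1` gives 2800 nM in this assay, and compound 2 `O=S(=O)(NCCNCc1ccc(-c2ccccc2)cc1)c1cc(C(F)(F)F)cc(C(F)(F)F)c1` gives 2400 nM. Compound 4 `O=S(=O)(NCCCNCc1ccc(Br)cc1)c1cc(C(F)(F)F)cc(C(F)(F)F)c1` carries 4-bromophenyl in place of 3,4-dimethoxyphenyl on a saturated chain carbon bound to an amine nitrogen. For the measured compounds named here, the one measured step that bears on this position is a 2.5-fold higher number from compound 1 to compound 3 (0.40 log units; beyond the scatter); the change to compound 4 runs in the opposite sense, trading the ring with two methoxy groups for a ring with a single bromine, so a lower number in this assay is expected, of about the size a 2.3-fold lower number from compound 3 to compound 4 (0.37 log units; beyond the scatter). Compound 2 differs in the chain as well, so its value only marks the range seen. Compound 4 is therefore estimated at 3000 nM, within 1400 nM to 6500 nM.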

Compound 4, concentration for 50% growth inhibition: 2500 nM
Estimate against measurement, compound 4: 1.2-fold (0.08 log units) above; the range from low to high includes it.
By their numbers in this assay, from the lowest: compounds 2, 4 and 1 (each within the scatter of the next); then compound 3.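

Moving from 3,4-dimethoxyphenyl to 4-bromophenyl on this saturated chain carbon lowers the number (a 2.8-fold lower number from compound 3 to compound 4 (0.45 log units; beyond the scatter)). Bromo and tert-butyl on the aromatic carbon are not separated (a 1.1-fold lower number from compound 1 to compound 4 (0.05 log units; within the scatter)), so two quite different groups read alike here, and both stand apart from 3,4-dimethoxyphenyl in compound 3. Nothing at hand explains this difference. On these data alone, whether a single methoxy group on the ring behaves like 3,4-dimethoxyphenyl or like bromo remains open. So does the reading for an unsubstituted phenyl or a nitrile in that place.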